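Turning one stereocentre in the 3-methylphenyl compound

This account rests on a few compounds, and the source may have more. Where it says the series, first, only, none or still open, it means among the compounds named here.

In a functional assay on MDA-MB-231 cells (Homo sapiens) for inhibition, read by MTT assay, with a stated time of 72 h (a lower number here means a stronger inhibitor, a higher number a weaker inhibitor), compound 1 (`CC1=NN(c2ccccc2)C(=O)[C@]12C(=O)C=CC[C@H]2c1ccccc1[N+](=O)[O-]`) gives 32400 nM, compound 2 (`CC1=NN(c2ccccc2)C(=O)[C@]12C(=O)C=CC[C@H]2c1ccc(C)cc1`) gives 5720 nM and compound 3 (`CC1=NN(c2ccccc2)C(=O)[C@]12C(=O)C=CC[C@H]2c1cccc(C)c1`) gives 10300 nM. Compound 3 thus lies within the scatter of compound 2, with a 1.8-fold higher number from compound 2 to compound 3 (0.26 log units; within the scatter), and beyond the scatter of compound 1, with a 3.1-fold lower number from compound 1 to compound 3 (0.50 log units; beyond the scatter). Compound 4 (`CC1=NN(c2ccccc2)C(=O)[C@]12C(=O)C=CC[C@@H]2c1cccc(C)c1`) is its partner: the two compounds have the same atoms and bonds and differ only in configuration as drawn: 1 of 2 stereo elements differ; a stereocentre at a saturated ring carbon is drawn S in compound 3 and R in compound 4. Within the data shown here, no measured step changes configuration. The nearest evidence is the aryl swaps on that carbon, such as a 5.7-fold lower number from compound 1 to compound 2 (0.75 log units; beyond the scatter), and these set only a rough scale and no direction. The expected result is a 1.0-fold lower number from compound 3 to compound 4 (0.01 log units; within the scatter), with no real change anticipated beyond the scatter. For compound 4 the estimated value is 10000 nM, with a range of 3500 nM to 30000 nM.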

Compound 4, half-maximal inhibitory concentration: 8000 nM
The estimate for compound 4 lay 1.3-fold (0.10 log units) above the measured number; low and high end bracket the measured number.
By their numbers in this assay, from the lowest: compounds 2, 4 and 3 (each within the scatter of the next); then compound 1.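

Among these compounds, this is the first step at this saturated ring carbon that changes configuration and not the aryl group, and in this assay it gives a 1.3-fold lower number from compound 3 to compound 4 (0.11 log units; within the scatter). Turning this stereocentre from S to R thus leaves the number within the scatter for the 3-methylphenyl pair, and neither drawn form is favoured. The comparison isolates this one change: the fact that compounds 3 and 4 differ only in the configuration as drawn.

The compounds shown leave open whether the same holds with 4-methylphenyl or 2-nitrophenyl on that carbon, or when the other stereocentre is turned. They also leave open what an amine or a carboxylic acid on that aryl group would do.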